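Swapping the halogenated benzothiazole for a benzothiazolylamino group

This account rests on a few compounds, and the source may have more. Where it says the series, first, only, none or still open, it means among the compounds named here.

Of the compounds shown here, two sharing one core have been measured in a physicochemical assay, read by spectrophotometry, with a stated time of 10 min; a higher number here means a weaker inhibitor, a lower number a stronger inhibitor. Compound 1 `O=c1cc(-c2ccccc2)oc2cc(OCCCCNc3nc4ccc(I)cc4s3)cc(O)c12` gives 9.84 ug/mL. Compound 2 `O=c1cc(-c2ccccc2)oc2cc(OCCCCNc3nc4c(F)cc(F)cc4s3)cc(O)c12` gives 5.76 ug/mL. Going by the values given here, the only step between them, a 1.7-fold lower number from compound 1 to compound 2 (0.23 log units; within the scatter), is within the scatter, so on the numbers so far compound 2 holds the lowest value of the two, but it cannot be told apart from compound 1.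

Compound 3 `O=c1cc(-c2ccccc2)oc2cc(OCCCCNNc3nc4ccccc4s3)cc(O)c12` has not yet been measured in this assay. It differs from compound 2 by (1,3-benzothiazol-2-yl)amino in place of 4,6-difluoro-1,3-benzothiazol-2-yl on an amine nitrogen: the two fluorine atoms are gone, and a second nitrogen now sits between the chain and the bicyclic group. Among the compounds with values here, the one measured step bears on this only loosely, since the step from compound 1 to compound 2 merely exchanged one halogen pattern for another on the same bicyclic group and stayed within the scatter. Within the data shown here, no step shows what removing the halogens or adding the extra nitrogen does. The expectation is therefore no step beyond the scatter in this assay. Compound 3 is expected to give 7.5 ug/mL, with a range from 3 ug/mL to 18 ug/mL. That estimate means an expected step of a 1.3-fold higher number from compound 2 to compound 3 (0.11 log units; within the scatter).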

Compound 3, half-maximal inhibitory concentration: 8.73 ug/mL
For compound 3 the middle estimate is 1.2-fold (0.07 log units) below the measured one; low and high end bracket the measured number.
By their numbers in this assay, from the lowest: compounds 2, 3 and 1 (each within the scatter of the next).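

In this assay the halogen-free (1,3-benzothiazol-2-yl)amino group was set against both halogenated groups on the amine nitrogen, which gives a 1.5-fold higher number from compound 2 to compound 3 (0.18 log units; within the scatter) and also a 1.1-fold lower number from compound 1 to compound 3 (0.05 log units; within the scatter) at the same place. The earlier pair compared only one halogen pattern with another, whereas these steps show that a group with no halogen at all, and with one more nitrogen, also cannot be told apart from either halogenated group in this assay. All three compounds therefore remain within the scatter of one another, and nothing measured here accounts for these numbers.

Both new steps remove the halogens and add the nitrogen in a single change, so the contribution of each stays unresolved; a plain 1,3-benzothiazol-2-yl group bonded directly to the amine nitrogen would be needed to separate them. As far as these compounds go, it also remains open whether any change at this position can move the number beyond the scatter, for example a carboxylic acid on the bicyclic group, or a longer chain linking it to the shared core.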